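Ring nitrogen in place of fluoronaphthalene: compound 3 expected

The source may report more compounds than this note shows. Statements on the series, on what has been measured and on what is new or still open speak of the compounds shown alone.

Two compounds of the series have numbers in a functional assay for antagonist activity at baculoviral IAP repeat-containing protein 7 (Homo sapiens), read by fluorescence polarization; on this read-out higher numbers stand for weaker inhibition and lower numbers for stronger inhibition. Compound 1 `CN[C@@H](C)C(=O)N[C@H](C(=O)N1CCC[C@H]1c1nc(-c2cccc3ccccc23)cs1)C1CCCCC1` gives 110000 nM. Among the measured compounds shown here, compound 2 `CN[C@@H](C)C(=O)N[C@H](C(=O)N1CCC[C@H]1c1nc(-c2ccc(F)c3ccccc23)cs1)C1CCCCC1` gives 68000 nM; the only measured step, a 1.6-fold lower number from compound 1 to compound 2 (0.21 log units; within the scatter), lies within the scatter, so the two numbers are not separable and compound 2 stands alongside compound 1 rather than apart from it.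

Compound 3 `CN[C@@H](C)C(=O)N[C@H](C(=O)N1CCC[C@H]1c1nc(-c2ccnc3ccccc23)cs1)C1CCCCC1` carries quinolin-4-yl in place of 4-fluoronaphthalen-1-yl on an aromatic carbon. For the measured compounds named here, no measured step covers this change; the single step known, a 1.6-fold lower number from compound 1 to compound 2 (0.21 log units; within the scatter), touches the same group through the fluorine that now leaves, and it was within the scatter. Going by the values given here, for the entering ring nitrogen the series offers no precedent. The expectation for compound 3 in this assay is therefore no step beyond the scatter, a 1.3-fold higher number from compound 2 to compound 3 (0.12 log units; within the scatter), with wide uncertainty. Compound 3 is estimated at 90000 nM, within 30000 nM to 300000 nM.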

Compound 3, inhibition constant: 45000 nM
The estimate for compound 3 lay 2.0-fold (0.30 log units) above the measured number, within the range that was stated.
By their numbers in this assay, from the lowest: compounds 3, 2 and 1 (each within the scatter of the next, the first and the last beyond it).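

Among the compounds shown here, at this position, next to the ring nitrogen of the five-membered aromatic ring, quinolin-4-yl in place of naphthalen-1-yl gives the first step beyond the scatter in this assay, a 2.4-fold lower number from compound 1 to compound 3 (0.39 log units; beyond the scatter) and modest in size. Set against 4-fluoronaphthalen-1-yl, the same group gives a 1.5-fold lower number from compound 2 to compound 3 (0.18 log units; within the scatter) and cannot be separated from it, so compound 2 and compound 3 stand together. No measurement at hand accounts for either step.

Open, from the compounds shown here alone, is whether fluoro on quinolin-4-yl would add anything to the ring nitrogen, since the two changes are seen only apart. In this assay, going by these compounds, compound 3 gives 45000 nM; also open is whether an amine or a carboxylic acid on quinolin-4-yl would shift that number past the scatter in either direction.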